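The compounds below may be only part of what the source reports. "The series", "measured", "known", "first", "only" and "open" are said of these compounds alone.

Measured so far in an assay (Rattus norvegicus) for inhibition of Fatty-acid amide hydrolase 1 (Homo sapiens); a higher number here means a weaker inhibitor, a lower number a stronger inhibitor:
compound 1, `Nc1cccc(-c2cnc(C(=O)CCCCCCc3ccccc3)o2)c1`: 19 nM
compound 2, `COc1ccc(-c2cnc(C(=O)CCCCCCc3ccccc3)o2)cc1`: 100 nM
compound 3, `Cc1cccc(-c2cnc(C(=O)CCCCCCc3ccccc3)o2)n1`: 3.3 nM

Compound 3 gives the lowest number of the three. Its nearest neighbour is compound 1, reached by a 5.8-fold lower number from compound 1 to compound 3 (0.76 log units; beyond the scatter); the gap to compound 2 is wider, a 30-fold lower number from compound 2 to compound 3 (1.48 log units; beyond the scatter). The pair compound 1 to compound 2 shows a 5.3-fold higher number from compound 1 to compound 2 (0.72 log units; beyond the scatter). All three steps concern the same position on the shared core, the aromatic carbon that carries the aryl group, and all three lie beyond the scatter.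

Compound 4, `O=C(CCCCCCc1ccccc1)c1ncc(-c2nnn[nH]2)o1`, continues at that position: 1H-tetrazol-5-yl in place of 6-methylpyridin-2-yl on an aromatic carbon. Within the data shown here, no measured step covers this replacement. What the series shows is that exchanging one group for another at this carbon has moved the number by a modest to a large step in each case, in either direction, and that compound 3 already stands at the low end. Among the measured compounds shown here, a further move downward of similar size has no precedent here, so compound 4 is expected to give a higher number than compound 3, by a step of the order of those seen, a 12-fold higher number from compound 3 to compound 4 (1.08 log units; beyond the scatter), with wide uncertainty. The estimate for compound 4 is 40 nM, expected between 5 nM and 400 nM.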

Compound 4, inhibition constant: 63 nM
Estimate against measurement, compound 4: 1.6-fold (0.20 log units) below; the range from low to high includes it.
By their numbers in this assay, from the lowest: compound 3; then compound 1; then compounds 4 and 2 (each within the scatter of the next).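

In the notes on this carbon, a five-membered aromatic ring with 4 hetero atoms now stands in the series, and in this assay the exchange of 6-methylpyridin-2-yl for 1H-tetrazol-5-yl costs a large step (a 19-fold higher number from compound 3 to compound 4 (1.28 log units; beyond the scatter)), so the low number of compound 3 does not carry over to this smaller group with its hydrogen-bond donor. Against the two substituted phenyl groups the result splits: 1H-tetrazol-5-yl cannot be told apart from 4-methoxyphenyl (a 1.6-fold lower number from compound 2 to compound 4 (0.20 log units; within the scatter)), while 3-aminophenyl keeps a modest edge over it (a 3.3-fold higher number from compound 1 to compound 4 (0.52 log units; beyond the scatter)), so a group with one ring, fewer heavy atoms and more hydrogen-bond acceptors can match one of the phenyl compounds without reaching compound 1 or compound 3. No measurement at hand accounts for any of these differences.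

Still open, going by these compounds, is whether the low number of compound 3 depends on its methyl group or on its ring nitrogen, which an unsubstituted pyridin-2-yl group would separate. Equally open, on these data alone, is whether the hydrogen-bond donor of the tetrazole matters, which a methyl group on the tetrazole ring or a carboxylic acid at this carbon would test.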